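The source may hold more compounds than are shown below. What is called first, only, known or untested is meant among the compounds shown, and "the series" means these compounds.

Measured in a toxicity assay on MT4 cells (Homo sapiens) for cytotoxicity, read by MTT assay, with a stated time of 5 days; on this read-out lower numbers stand for higher toxicity in this test and higher numbers for lower toxicity in this test:
- compound 1 `Cc1cnc(Nc2ccc(C#N)cc2)nc1Nc1c(F)cc(-c2ccoc2)cc1F`: 4200 nM
- compound 2 `Cc1cnc(Nc2ccc(C#N)cc2)nc1Nc1c(F)cc(-c2ccc(C#N)nc2)cc1F`: 62000 nM
- compound 3 `Cc1cc(-c2cccc3cc[nH]c23)cc(C)c1Nc1ccnc(Nc2ccc(C#N)cc2)n1`: 1000 nM

Compound 3 holds the lowest of the three numbers, and so shows the highest toxicity in this small set, with compound 1 the nearer of the other two and compound 2 the furthest away.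

Compound 4 `Cc1cc(-c2ccnc(F)c2)cc(C)c1Nc1ccnc(Nc2ccc(C#N)cc2)n1` has 2-fluoropyridin-4-yl in place of 1H-indol-7-yl on an aromatic carbon. Among the measured compounds shown here, no measured step makes this exact exchange. The closest evidence is a 15-fold higher number from compound 1 to compound 2 (1.17 log units; beyond the scatter), a large step beyond the scatter, with 6-cyanopyridin-3-yl in place of furan-3-yl. That step also brings in a substituted pyridine ring, but on a core that differs from the core of compound 3, and it leaves from a different group, so it gives the direction more firmly than the size. A moderate rise in this assay is therefore expected, smaller than that step. The expected shift is a 5.0-fold higher number from compound 3 to compound 4 (0.70 log units; beyond the scatter). For compound 4 the estimated value is 5000 nM, with an expected range from 1500 nM to 25000 nM.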

Compound 4, half-maximal cytotoxic concentration: 6000 nM
Compound 4: the middle estimate sits 1.2-fold (0.08 log units) below what was measured; the measured number falls inside the stated range.
By their numbers in this assay, from the lowest: compound 3; then compounds 1 and 4 (each within the scatter of the next); then compound 2.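

In this assay, the ring on the carbon meta to two methyl groups also matters on the core of compound 3, with a 6.0-fold higher number from compound 3 to compound 4 (0.78 log units; beyond the scatter) as 2-fluoropyridin-4-yl replaces 1H-indol-7-yl. The rise runs in the same direction as a 15-fold higher number from compound 1 to compound 2 (1.17 log units; beyond the scatter) on the other core, so in both listed exchanges a substituted pyridine enters and the number goes up, although the two groups that leave are different. Heavy atoms, hydrogen-bond donors and hydrogen-bond acceptors all change together in this single exchange, and no measurement on hand accounts for the rise.

The compounds shown do not separate the part played by the fluorine from that of the pyridine ring. They also leave open how a small group at this carbon, such as an amine or a carboxylic acid, would read in this assay.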